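Swapping the acyl side chain of compound 2 for an amino chain

The source may hold more compounds than are shown below. What is called first, only, known or untested is meant among the compounds shown, and "the series" means these compounds.

Three related compounds have been measured in an assay on HEK293 cells for displacement of a labelled ligand from Melanocortin receptor 4 (Homo sapiens); on this read-out lower numbers stand for stronger inhibition and higher numbers for weaker inhibition. Compound 1 `Cc1ccc(N2CCN(C(=O)[C@H](C)Cc3ccc(Cl)cc3F)CC2)c([C@@H](N)CC(C)C)c1` gives 20 nM, and compound 3 `CC(C)C[C@H](N)c1ccccc1N1CCN(C(=O)[C@H](C)Cc2ccc(Cl)cc2Cl)CC1` gives 16 nM. Compound 2 `COc1ccc(CC(C)C(=O)N2CCN(c3ccc(C(F)(F)F)cc3[C@@H](N)CC(C)C)CC2)cc1` gives 120 nM in this assay, which is the highest of the three numbers, and therefore the weakest binding; its gaps to compound 1 and to compound 3 both lie beyond the usual scatter.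

The unmeasured compound 4 `CC(C)C[C@H](N)c1cc(C(F)(F)F)ccc1N1CCN(C(=O)CCNC2CCCCC2)CC1` differs from compound 2 in one place: 2-(cyclohexylamino)ethyl in place of 1-(4-methoxybenzyl)ethyl on a carbonyl carbon. Among the measured compounds shown here, nothing measured here shows what happens when an aromatic group on that carbonyl carbon is exchanged for a non-aromatic ring carried on an amino chain, so no step of a known size can guide the expectation. Both stronger-binding compounds keep an aromatic ring in that position, and compound 4 gives it up. The step from compound 2 is therefore expected to be a 2.5-fold higher number from compound 2 to compound 4 (0.40 log units; beyond the scatter), toward a weaker number. For compound 4 the estimated value is 300 nM, with a range from 60 nM to 1500 nM.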

Compound 4, inhibition constant: 4800 nM
Compound 4: the middle estimate sits 16-fold (1.20 log units) below what was measured, outside the stated range (above it).
By their numbers in this assay, from the lowest: compounds 3 and 1 (each within the scatter of the next); then compound 2; then compound 4.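

Among the compounds shown here, the group on this carbonyl carbon has a large effect on binding: 2-(cyclohexylamino)ethyl in place of 1-(4-methoxybenzyl)ethyl gives a 40-fold higher number from compound 2 to compound 4 (1.60 log units; beyond the scatter) and is the only step here that changes a single place. That one place still holds more than one difference, since a six-membered aromatic ring gives way to a non-aromatic one and the chain gains a nitrogen carrying a hydrogen-bond donor. Nothing available here bears on why the number rises so far.

The compounds shown do not tell whether the loss follows the change of ring or the nitrogen in the chain. A 2-(phenylamino)ethyl group would pair the amino chain with an aromatic ring, and a 3-cyclohexylpropyl group would keep the non-aromatic ring on a carbon-only chain, so these two could pull the differences apart.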